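Swapping the aryl halogen on a chalcone-lactone conjugate

This account rests on a few compounds, and the source may have more. Where it says the series, first, only, none or still open, it means among the compounds named here.

Compound 1, `O=C(COc1ccc(C(=O)/C=C/c2cccc(Br)c2)cc1)N[C@H]1CCOC1=O`, is tested in a functional assay on MCF7 cells (Homo sapiens) for antiproliferative activity, read by MTT assay, with a stated time of 72 h (a higher number here means a weaker inhibitor, a lower number a stronger inhibitor), and in that setting compound 1 gives 28300 nM. Within the data shown here, this is the only number in the set: the other entry is a limit rather than a value. Compound 2, `Cc1cc(Cl)ccc1NCC(=O)N[C@H]1CCOC1=O`, with its shorter core lacking the enone bridge, reaches only > 64000 nM in this assay, a limit of the measurement and not a number, as the limit of > 64000 nM in this assay, at which 1 of the 2 values shown sits, records. Among the measured compounds shown here, no step between measured compounds can therefore be computed from these two entries.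

Compound 3, `O=C(COc1ccc(C(=O)/C=C/c2ccc(F)cc2)cc1)N[C@H]1CCOC1=O`, keeps the whole core of compound 1 and differs only at the aryl end of the double-bonded chain: 4-fluorophenyl in place of 3-bromophenyl on a double-bonded chain carbon bound to a double-bonded chain carbon. For the measured compounds named here, since no measured step exists for a change of this kind, the expectation for compound 3 rests on compound 1 alone. A halogen-for-halogen exchange on the same ring is expected to move the result little, so the estimated step from compound 1 a 1.2-fold higher number from compound 1 to compound 3 (0.09 log units; within the scatter) is taken to lie within, or only just beyond, the usual scatter. Compound 3 is thus estimated at 35000 nM in this assay, with a plausible range from 12000 nM to 90000 nM.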

Compound 3, half-maximal inhibitory concentration: > 64000 nM
Compound 3 ended at the assay's limit; the forecaster's own chance of this, stated with the estimate: 20%; at least 1.8-fold (0.26 log units) between middle value and limit.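

The exchange of 3-bromophenyl for 4-fluorophenyl on a double-bonded chain carbon bound to a double-bonded chain carbon, with the rest of the core of compound 1 unchanged, gives an at least 2.2-fold higher number from compound 1 to compound 3 (0.35 log units; beyond the scatter) in this assay. Among these compounds, this is the first sign that the aryl end of the chain is not indifferent to such an exchange, since even a swap between two halogen-bearing phenyl groups of equal heavy-atom count moves the result beyond the scatter, and the full enone-bearing core alone does not secure a measurable value. The entry for compound 3 is a limit and not a number, so the step fixes only a lower bound on the change, and the set now gathers at its ceiling: the limit of > 64000 nM in this assay, at which 2 of the 3 values shown sit.

The single step changes the halogen and the number in the group's name together, so the compounds shown cannot tell which of the two accounts for the loss. On these data alone, whether a plain phenyl group, or a phenyl group carrying a methoxy group or an amine, would keep a measurable value in this assay remains open.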